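The source may hold more compounds than are shown below. What is called first, only, known or untested is meant among the compounds shown, and "the series" means these compounds.

Compound 1 `COc1cc(C(=O)/C=C\Nc2ccc(-c3nc4cc(OC)c(OC)c(OC)c4s3)cc2C)cc(OC)c1OC`: 22800 nM in a functional assay on MIA PaCa-2 cells (Homo sapiens) for antiproliferative activity, read by sulforhodamine B assay, with a stated time of 48 h; on this read-out lower numbers stand for stronger inhibition and higher numbers for weaker inhibition
Compound 2 `COc1cc(OC)c2sc(-c3ccc(N/C=C\C(=O)c4cc(OC)c(OC)c(OC)c4)cc3)nc2c1`: 26800 nM in this assay
Compound 3 `COc1cc(OC)c2sc(-c3ccc(N/C=C\C(=O)c4ccc(OC)c(O)c4)c(C)c3)nc2c1`: 22100 nM in this assay

All three measured compounds share a core and differ in the aromatic ring attached to the carbonyl carbon and in the methoxy pattern on the other end. In this assay compound 3 gives 22100 nM, the lowest of the three numbers, yet its nearest neighbour is compound 1, and the gap between them, like the gap to compound 2, falls within the usual scatter of this kind of measurement, so no order among the three can be claimed.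

Compound 4 `COc1cc(OC)c2sc(-c3ccc(N/C=C\C(=O)c4cc(OC)c(OC)c(OC)c4)c(C)c3)nc2c1` has not been measured. It differs from compound 3 in one place: 3,4,5-trimethoxyphenyl in place of 3-hydroxy-4-methoxyphenyl on a carbonyl carbon. The entering 3,4,5-trimethoxyphenyl is the same ring that compound 1 and compound 2 carry on their carbonyl carbon, and in this assay compound 1 gives 22800 nM while compound 2 gives 26800 nM, both close to the number of compound 3. Among the compounds with values here, no single-change step between measured compounds is available, so the expectation rests on these values alone. The step is therefore expected to be small, in no clear direction, and not beyond the scatter: a 1.1-fold higher number from compound 3 to compound 4 (0.04 log units; within the scatter). Compound 4 is estimated at 24000 nM, with a range from 10000 nM to 55000 nM.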

Compound 4, half-maximal inhibitory concentration: 17000 nM
Beside the measured number, compound 4's estimate is 1.4-fold (0.15 log units) above it; the measured number falls inside the stated range.
By their numbers in this assay, from the lowest: compounds 4, 3, 1 and 2 (each within the scatter of the next).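

In this assay, within the data shown here, placing 3,4,5-trimethoxyphenyl on the carbonyl carbon in place of 3-hydroxy-4-methoxyphenyl gives a 1.3-fold lower number from compound 3 to compound 4 (0.11 log units; within the scatter), so at this position the change from 1 hydrogen-bond donor to 0 produces no step that can be told from the scatter. Compound 4 also connects the series through two further single changes: methyl in place of hydrogen on an aromatic carbon gives a 1.6-fold lower number from compound 2 to compound 4 (0.20 log units; within the scatter), and hydrogen in place of methoxy on an aromatic carbon gives a 1.3-fold lower number from compound 1 to compound 4 (0.13 log units; within the scatter), so none of the three changes can be separated from the scatter. No measurement shown here offers an explanation for these small steps.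

Every step stays within the scatter. The compounds shown do not reveal which parts of the structure this read-out responds to, if any. As far as these compounds go, it remains open whether a different kind of group on the carbonyl carbon, such as a ring carrying an amine or a carboxylic acid, or a longer chain in place of the methyl on the aromatic carbon, would produce a step beyond the scatter.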